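A few compounds are considered here, and "the series" means these few. Any claim that something is new, unique, unknown or untested is made for them only; others in the source may bear on it.

Measured compounds:
Compound 1, `O=C(COc1ccncc1-c1ccc2ccccc2c1)N1CCOCC1`: 9%
Compound 2, `O=C(/C=C/c1ccncc1-c1ccc2ccccc2c1)N1CCOCC1`: 99%
Compound 3, `O=C(O)/C=C/c1ccncc1-c1ccc2[nH]ccc2c1`: 102%

In an assay on a protein complex for inhibition of CDK8/Cyclin C (Homo sapiens), with a stated time of 1 h, tested at 10 uM (on this read-out higher numbers stand for more inhibition at the one concentration tested (going by the name of the read-out) and lower numbers for less inhibition), compound 1 gives 9%, the lowest of the three numbers. Compound 2 gives 99% and compound 3 gives 102% in this assay; both stand far above compound 1, beyond the scatter, while compounds 2 and 3 sit within the scatter of each other, so nothing orders them. Among the compounds with values here, compound 1 and compound 4 share the same core with the ether-linked acetamide, which compounds 2 and 3 lack; no step between measured compounds isolates any single change here, so the low number of compound 1 cannot be traced to one part of it.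

Compound 4, `CNC(=O)COc1ccncc1-c1ccc2ccccc2c1`, has not been measured. It differs from compound 1 in one place: methylamino in place of morpholin-4-yl on a carbonyl carbon. Since compound 1 itself gives 9%, a low number, the amide change is expected to leave the read-out about where it is, and the step of a number 3 percentage points higher from compound 1 to compound 4 (within the scatter) is expected to lie within the scatter, with no direction that can be relied upon. Compound 4 is therefore estimated at 12%, with a range from -5% to 35%.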

Compound 4, a percentage reported as inhibition, at one concentration (the size of the read-out at that concentration, not a potency): 4%
Compound 4: middle estimate off by 8 percentage points, on the high side, and the stated range covers the measured number.
By their numbers in this assay, from the lowest: compounds 4 and 1 (each within the scatter of the next); then compounds 2 and 3 (each within the scatter of the next).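

In this assay, methylamino in place of morpholin-4-yl on a carbonyl carbon gives a number 5 percentage points lower from compound 1 to compound 4 (within the scatter), the first step available at this place. The read-out stays low with either group, so the morpholin-4-yl ring alone does not account for the low number of compound 1, and a ring on this carbonyl carbon is not needed to keep it low. Nothing measured here offers a reason for this result.

Still open, going by these compounds, is whether a different group on this carbonyl carbon, such as a carboxylic acid in place of the amide or a longer amine, would change the read-out. Within the data shown here, no single step yet connects compounds 1 and 4 to compounds 2 and 3, so the part of the structure that separates these two pairs remains unidentified.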